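A few compounds are considered here, and "the series" means these few. Any claim that something is new, unique, unknown or untested is made for them only; others in the source may bear on it.

Values in a functional assay on MDA-MB-231 cells (Homo sapiens) for antiproliferative activity, read by MTT assay; a lower number here means a stronger inhibitor, a higher number a weaker inhibitor:
- Compound 1 `CCCCCCCCCCCCCCCc1cc(=O)c2c(O)c(C)c(OCOC)cc2o1`: > 87000 nM, a limit of the assay.
- Compound 2 `CCCCC/C=C\C/C=C\CCCCCCCc1cc(=O)c2c(O)c(C)c(OCOC)cc2o1`: > 87000 nM, a limit of the assay.
- Compound 3 `CCCCC/C=C\C/C=C\CCCCCCCc1cc(=O)c2c(O)c(C)c(O)cc2o1`: 16100 nM.

Among the compounds with values here, compound 3 holds the only actual number in this short series, so it has no measured neighbour to be ranked against by size. The reference at the weak end is the limit of > 87000 nM in this assay, at which 2 of the 3 values shown sit.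

Compound 4 `CCCCCCCCCCCCCCCc1cc(=O)c2c(O)c(C)c(O)cc2o1` is next, and its change from compound 3 is octyl in place of deca-1,4-dien-1-yl on a saturated chain carbon, seven bonds along the chain from an aromatic carbon.

Within the data shown here, two measured steps bear on this. The same exchange, run in the opposite direction and with methoxymethyl on the oxygen, is a step that the two limits leave unreadable from compound 1 to compound 2, so it gives no size to carry over. The other is an at least 5.4-fold lower number from compound 2 to compound 3 (0.73 log units; beyond the scatter), and compound 4 shares with compound 3 the hydrogen on that oxygen. A readable number is therefore more likely than a limit, although this is not certain.

With no readable size for the chain exchange, only a small shift toward a weaker value is expected, and not one clearly beyond the scatter. The estimated step is a 1.5-fold higher number from compound 3 to compound 4 (0.17 log units; within the scatter). For compound 4 the expected value is 24000 nM, with an estimated range of 9000 nM to 62000 nM.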

Compound 4, half-maximal inhibitory concentration: 42800 nM
Compound 4: middle estimate off by 1.8-fold (0.25 log units), on the low side; low and high end bracket the measured number.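

In this assay, the chain exchange now has a readable size: with hydrogen on the oxygen, octyl in place of deca-1,4-dien-1-yl gives a 2.7-fold higher number from compound 3 to compound 4 (0.42 log units; beyond the scatter), so on this core the chain with two double bonds gives the lower number. Hydrogen in place of methoxymethyl is now also seen on the saturated chain, with an at least 2.0-fold lower number from compound 1 to compound 4 (0.30 log units; that floor lies within the scatter); this step is only a floor. The change lowers the number on both chains, and no compound shown goes against this, but the two sizes cannot be ranked: the same change on two cores in this assay, an at least 5.4-fold lower number (0.73 log units; beyond the scatter) from compound 2 to compound 3 and an at least 2.0-fold lower number (0.30 log units; that floor lies within the scatter) from compound 1 to compound 4; the limit leaves it open whether they differ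

Whether the chain exchange has any effect with methoxymethyl on the oxygen stays unreadable, and both compounds carrying that group stand at the limit: the limit of > 87000 nM in this assay, at which 2 of the 4 values shown sit. The entering and leaving groups differ in both carbon count and double bonds, so a saturated decyl in the same place, or a chain carrying a carboxylic acid, would be needed to show which feature tracks with the lower number.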